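Sulfonamide series: chloropyridyl replaces ethylphenyl on sulfonyl

The source may hold more compounds than are shown below. What is called first, only, known or untested is meant among the compounds shown, and "the series" means these compounds.

Three members of the shared core have been tested in a functional assay on DLD-1 cells (Homo sapiens) for antiproliferative activity, read by CellTiter-Glo, with a stated time of 72 h; on this read-out higher numbers stand for weaker inhibition and lower numbers for stronger inhibition. Compound 1 `CCc1ccc(S(=O)(=O)N2CCC(N3CCC(C)CC3)CC2)cc1` returns only a limit, > 5000 nM. Compound 2 `COC(=O)c1ccc(S(=O)(=O)N2CCC(N3CCC(C)CC3)CC2)cc1` also returns only a limit, > 5000 nM. Compound 3 `CCCCOc1ccc(S(=O)(=O)N2CCC(N3CCC(C)CC3)CC2)cc1` gives a measured number, 2300 nM. Of the steps between them, an at least 2.1-fold lower number from compound 1 to compound 3 (0.33 log units; beyond the scatter) and an at least 2.1-fold lower number from compound 2 to compound 3 (0.33 log units; beyond the scatter) are readable, while a step that the two limits leave unreadable from compound 1 to compound 2 cannot be sized. Compound 1 therefore stands at the limit of > 5000 nM in this assay, at which 2 of the 3 values shown sit, with no number of its own.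

Compound 4 `CC1CCN(C2CCN(S(=O)(=O)c3ccc(Cl)nc3)CC2)CC1` differs from compound 1 in one place: 6-chloropyridin-3-yl in place of 4-ethylphenyl on a sulfonyl sulfur. Among the measured compounds shown here, no measured step exchanges the aryl on the sulfonyl sulfur for a heteroaryl, so none bears directly on this change; the steps of an at least 2.1-fold lower number from compound 1 to compound 3 (0.33 log units; beyond the scatter) and an at least 2.1-fold lower number from compound 2 to compound 3 (0.33 log units; beyond the scatter) show only that a change on the aromatic carbon can bring the number under the limit, and the step that the two limits leave unreadable from compound 1 to compound 2 shows that it need not. With compound 1 at a limit, the expected step that the limit leaves unreadable from compound 1 to compound 4 is taken as none beyond the scatter. Compound 4 is estimated at 6000 nM, within 2500 nM to 15000 nM in this assay, most likely again as a limit.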

Compound 4, half-maximal inhibitory concentration: 3700 nM
Compound 4: the middle estimate sits 1.6-fold (0.21 log units) above what was measured; the range from low to high includes it.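

In this assay, 6-chloropyridin-3-yl in place of 4-ethylphenyl on the sulfonyl sulfur gives an at least 1.3-fold lower number from compound 1 to compound 4 (0.13 log units; that floor lies within the scatter). Among the compounds shown, an aromatic ring with a hetero atom is thus tolerated at this position and still returns a measured number, and compound 3 is no longer the only member that does. The floor of this step lies within the scatter, so no gain can be claimed, and the true size stays unread with compound 1 only a limit: the limit of > 5000 nM in this assay, at which 2 of the 4 values shown sit.

The shares of the ring nitrogen and of the chlorine in the value of compound 4 stay open, with neither present alone in the compounds shown. Also open, going by these compounds, is how an amine or a carboxylic acid in place of that chlorine would read.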